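This account rests on a few compounds, and the source may have more. Where it says the series, first, only, none or still open, it means among the compounds named here.

Measured in a functional assay on MCF7 cells (Homo sapiens) for antiproliferative activity, read by MTT assay, with a stated time of 72 h; a higher number here means a weaker inhibitor, a lower number a stronger inhibitor:
- Compound 1 `COc1cc(/C=C/c2ccc(C3=C(c4ccc(O)cc4)C4CC(S(=O)(=O)Oc5ccccc5)C3O4)cc2)cc(OC)c1`: > 100000 nM, a limit and not a number
- Compound 2 `COc1cc(/C=C/c2ccc(C3=C(c4ccc(O)cc4)C4CC(S(=O)(=O)Oc5ccc(Br)cc5)C3O4)cc2)cc(OC)c1`: > 100000 nM, a limit and not a number
- Compound 3 `COc1cc(/C=C/c2ccc(C3=C(c4ccc(O)cc4)C4CC(S(=O)(=O)Oc5cccc(OC)c5)C3O4)cc2)cc(OC)c1`: 77100 nM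

Compound 1 stands at the limit of > 100000 nM in this assay, at which 2 of the 3 values shown sit, so its potency is known only as a limit. Compound 4 `O=S(=O)(Oc1ccccc1)C1CC2OC1C(c1ccc(/C=C/c3cc(O)cc(O)c3)cc1)=C2c1ccc(O)cc1` keeps the rest of compound 1 but carries 3,5-dihydroxyphenyl in place of 3,5-dimethoxyphenyl on a double-bonded chain carbon bound to a double-bonded chain carbon.

Going by the values given here, none of the measured steps touches this group. Bromo in place of hydrogen gives a step that the two limits leave unreadable from compound 1 to compound 2. Methoxy in place of hydrogen gives an at least 1.2-fold lower number from compound 1 to compound 3 (0.11 log units; that floor lies within the scatter). Swapping 4-bromophenyl for 3-methoxyphenyl gives an at least 1.2-fold lower number from compound 2 to compound 3 (0.11 log units; that floor lies within the scatter). These steps therefore give no direct size for the new change, only a sign of where these compounds sit in this assay. Among the compounds with values here, the only true number is that of compound 3, at 77100 nM, so a value in that region is the cautious expectation. There is also a real chance that compound 4 will give another limit.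

The expected change is an at least 2.0-fold lower number from compound 1 to compound 4 (0.30 log units; that floor lies within the scatter), a modest move toward a lower number. Compound 4 is estimated at 50000 nM, with an expected range from 15000 nM to 150000 nM.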

Compound 4, half-maximal inhibitory concentration: 20100 nM
Estimate against measurement, compound 4: 2.5-fold (0.40 log units) above, and the stated range covers the measured number.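

In this assay, replacing 3,5-dimethoxyphenyl with 3,5-dihydroxyphenyl on a double-bonded chain carbon bound to a double-bonded chain carbon gives an at least 4.9-fold lower number from compound 1 to compound 4 (0.69 log units; beyond the scatter). Going by these compounds alone, the earlier steps all changed the phenyl group on the oxygen, so this is the first readable sign that this other end of the molecule also affects the result, and here the change adds 2 hydrogen-bond donors. Compound 1 gives only a limit, so the true size of this step stays unknown: the limit of > 100000 nM in this assay, at which 2 of the 4 values shown sit.

The compounds shown leave open whether both hydroxy groups are needed, or whether an amine in their place would serve as well. They also leave open whether the same swap would have a similar effect on compound 2 or compound 3, which carry different groups on that oxygen.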